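The source may report more compounds than this note shows. Statements on the series, on what has been measured and on what is new or still open speak of the compounds shown alone.

The measured compounds:

Compound 1 `Cn1c(/C=C2\SC(=O)N(CC(=O)N3CCCCC3)C2=O)nc2ccccc21`; in a functional assay on DU-145 cells (Homo sapiens) for inhibition, read by MTT assay, with a stated time of 48 h (a lower number here means a stronger inhibitor, a higher number a weaker inhibitor), compound 1 gives > 50000 nM, which is a limit of the assay rather than a number.

Compound 2 `CC(C)n1c(/C=C2\SC(=O)N(CC(=O)N3CCCCC3)C2=O)nc2ccccc21`; in this assay compound 2 gives 42200 nM.

Compound 3 `COc1cc2c(cc1OC)CN(C(=O)CN1C(=O)S/C(=C\c3nc4ccccc4n3C(C)C)C1=O)CC2`; in this assay compound 3 gives 29700 nM.

Compounds 1 and 2 share one core and differ in a single place: methyl in place of isopropyl on an aromatic nitrogen. That change gave an at least 1.1-fold higher number from compound 2 to compound 1 (0.07 log units; that floor lies within the scatter). The number for compound 1 is a limit, so the true size of the step is not known; what is known is that the number did not become smaller, and compound 1 sits at the limit of > 50000 nM in this assay, at which 1 of the 3 values shown sits.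

Compound 3 carries a different core, and the difference between the two cores is not broken down here. Against compound 2 it stands within the scatter, so no order between the two can be read.

Compound 4 `COc1cc2c(cc1OC)CN(C(=O)CN1C(=O)S/C(=C\c3nc4ccccc4n3C)C1=O)CC2` has not been measured. It differs from compound 3 in exactly the same way that compound 1 differs from compound 2: methyl in place of isopropyl on an aromatic nitrogen. The place of the change is the same in both pairs, so the change is the same, made on another core.

Resting on the one measured example of this change, the step from compound 2 to compound 1, compound 4 is expected to give a number at least as high as compound 3, with a 1.3-fold higher number from compound 3 to compound 4 (0.13 log units; within the scatter) as the estimated step. The expected value for compound 4 in this assay is 40000 nM, estimated to lie between 20000 nM and 80000 nM, with a real chance that the assay reports only a limit.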

Compound 4, half-maximal inhibitory concentration: 37500 nM
For compound 4 the middle estimate is 1.1-fold (0.03 log units) above the measured one; measured number inside the range.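

In this assay, methyl in place of isopropyl on the aromatic nitrogen gives a 1.3-fold higher number from compound 3 to compound 4 (0.10 log units; within the scatter), so compound 3 and compound 4 cannot be put in any order, and on this core the change shows no effect that can be told apart from the ordinary spread of repeated measurements. Compound 1 gives > 50000 nM, which is a limit of the assay and not a number. From the compounds shown here alone, the two examples show nothing that sets the two cores apart, yet they also do not show that the change carries over from one core to the other at the same size, as the size of the first step stays unknown: the same change on two cores in this assay, an at least 1.1-fold higher number (0.07 log units; that floor lies within the scatter) from compound 2 to compound 1 and a 1.3-fold higher number (0.10 log units; within the scatter) from compound 3 to compound 4; the limit leaves it open whether they differ.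

The compounds shown carry only methyl or isopropyl on this nitrogen, so it stays open how an ethyl group, a longer chain or a chain ending in an amine would read in this assay. Also open, going by these compounds, is whether the same swap would give a step beyond the scatter on a third core, particularly one whose number lies well clear of the limit of the assay.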